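This account rests on a few compounds, and the source may have more. Where it says the series, first, only, none or still open, it means among the compounds named here.

Working notes on the series.

Compound 1 `Nc1nc(O)nc2ccccc12` is the smallest member, and in an assay for inhibition of Dihydrofolate reductase (Homo sapiens) (on this read-out higher numbers stand for higher potency (the scale is a negative logarithm) and lower numbers for lower potency), compound 1 gives 4.02. Compound 3 `Nc1nc(O)c2cc(Sc3ccc4ccccc4c3)ccc2n1` carries a different core; in this assay compound 3 gives 7.35, the highest of the three measured numbers. Compound 2 `Nc1nc(S)c2cc(Sc3ccc4ccccc4c3)ccc2n1` shares the core of compound 3 and in this assay compound 2 gives 6.64. The difference between the core of compound 1 and the core of compound 3 is not broken down here.

Within the measured set one single-point change is seen once: sulfanyl in place of hydroxy on an aromatic carbon and the step was a number 0.71 log units lower from compound 3 to compound 2 (beyond the scatter), a modest loss.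

Compound 4 `Nc1nc(S)nc2ccccc12` is not yet measured. It arises from compound 1 by sulfanyl in place of hydroxy on an aromatic carbon. Within the data shown here, this is the same kind of change as the one from compound 3 to compound 2, but not the same: in compound 4 the exchanged group sits between two ring nitrogen atoms and para to a fused ring, whereas in compound 2 it sits next to the ring nitrogen, ortho to a fused ring and opposite the ring nitrogen. Among the measured compounds shown here, with only one measured instance, on a different core and at a different place, the transfer is uncertain.

For compound 4 the step from compound 1 is expected to be a number 0.52 log units lower from compound 1 to compound 4 (beyond the scatter), resting on the loss seen in a number 0.71 log units lower from compound 3 to compound 2 (beyond the scatter). In this assay compound 4 is therefore expected to give about 3.5, plausibly between 2.8 and 4.3.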

Compound 4, logarithm of the reciprocal of the active concentration, log(1/C): 3.72
Beside the measured number, compound 4's estimate is 0.22 log units below it; the measured number falls inside the stated range.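

In this assay the exchange of hydroxy for sulfanyl on the smaller core reads as a number 0.30 log units lower from compound 1 to compound 4 (within the scatter), so on this core the change cannot be told apart from repeat-measurement noise. Set beside the earlier step, the two instances give no ground for calling the change different from one core to the other: the same change on two cores in this assay, a number 0.71 log units lower (beyond the scatter) from compound 3 to compound 2 and a number 0.30 log units lower (within the scatter) from compound 1 to compound 4, 0.41 log units apart, within the scatter of two such steps. Among these compounds, this supports carrying the change across these two cores only as a rough expectation of little or modest loss; it does not fix a common size for the step, since only two pairs exist, one step lies beyond the scatter and the other within it, and the exchanged group does not occupy the same place in the two pairs.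

The compounds shown leave open whether an amine or a methoxy group in place of hydroxy would behave alike on the core of compound 1 and the core of compound 3. Among the compounds shown here, they also leave open how the large gap between those two cores divides among its parts, since no single-point step connects them here.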